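From methoxy to hydroxy in a pair of growth inhibitors

The source may report more compounds than this note shows. Statements on the series, on what has been measured and on what is new or still open speak of the compounds shown alone.

Measured in a functional assay on DU-145 cells (Homo sapiens) for inhibition, read by trypan blue exclusion, with a stated time of 96 h (a lower number here means a stronger inhibitor of growth, a higher number a weaker inhibitor of growth), so far
- compound 1 `Cc1ccc(C)c(/C=C(\C(=O)c2ccc(Br)cc2)S(=O)(=O)Cc2ccc(F)cc2)c1` gives 1000 nM
- compound 2 `COc1ccc(/C=C(\C(=O)c2ccc(Br)cc2)S(=O)(=O)Cc2ccc(F)cc2)cc1` gives 25000 nM

Compound 2 with 25000 nM stands as the higher of the two numbers, so it is the weaker inhibitor of growth of this pair. Compound 3 `O=C(/C(=C\c1ccc(O)cc1)S(=O)(=O)Cc1ccc(F)cc1)c1ccc(Br)cc1` differs from it by one change, methoxy to hydroxy hydrogen in place of methyl on an oxygen on an aromatic ring on the same phenyl group, with hydrogen in place of methyl on an oxygen on an aromatic ring. For the measured compounds named here, the only measured step is a 25-fold higher number from compound 1 to compound 2 (1.40 log units; beyond the scatter) and it is large, but it exchanged a whole 2,5-dimethylphenyl group for 4-methoxyphenyl. It shows that this part of the molecule can matter, yet no measurement covers methoxy to hydroxy itself. A smaller step is therefore expected in this assay with an uncertain direction, leaning slightly towards a lower number. The expected change is a 2.1-fold lower number from compound 2 to compound 3 (0.32 log units; beyond the scatter) as a rough estimate. Compound 3 is estimated at 12000 nM with an expected range from 2500 nM to 50000 nM when it is measured.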

Compound 3, concentration for 50% growth inhibition: 10000 nM
Beside the measured number, compound 3's estimate is 1.2-fold (0.08 log units) above it; measured number inside the range.
By their numbers in this assay, from the lowest: compound 1; then compound 3; then compound 2.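

In this assay the change from methoxy to hydroxy gives a 2.5-fold lower number from compound 2 to compound 3 (0.40 log units; beyond the scatter) and so, unlike the earlier whole-group exchange, isolates the methyl on this oxygen as a modest but real contributor beyond the scatter. Even so, the 4-hydroxyphenyl group leaves a 10-fold higher number from compound 1 to compound 3 (1.00 log units; beyond the scatter) and thus most of the distance to the 2,5-dimethylphenyl group remains, which means that removing this methyl recovers only a small part of the gap between compound 1 and compound 2. Nothing available here explains either step.

On these data alone, it remains open whether an amine, a carboxylic acid or a longer chain such as ethoxy in place of hydroxy would lower the number further or raise it. Also open, as far as these compounds go, is whether the methoxy to hydroxy step keeps its size and direction when the rest of the molecule differs.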